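Substituent swap on the aromatic carbon, compound 3 to compound 4

This account rests on a few compounds, and the source may have more. Where it says the series, first, only, none or still open, it means among the compounds named here.

Measured in an assay on isolated protein for displacement of a labelled ligand from sodium-dependent dopamine transporter (Homo sapiens), tested at 1000 nM; on this read-out higher numbers stand for more inhibition at the one concentration tested (going by the name of the read-out) and lower numbers for less inhibition:
compound 1 `O[C@](Cc1ccccc1Br)(c1ccccc1)[C@@H]1CNCCO1`: 24.1%
compound 2 `O[C@](Cc1ccccc1)(c1ccccc1)[C@@H]1CNCCO1`: 5.5%
compound 3 `O[C@](Cc1ccccc1-c1ccccc1)(c1ccccc1)[C@@H]1CNCCO1`: 2.9%

Compound 3 gives the lowest of the three numbers; its gap to compound 2 is within the scatter, only compound 1 stands clearly apart, a number 21.2 percentage points lower from compound 1 to compound 3 (beyond the scatter).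

Compound 4 `O[C@](Cc1ccccc1SC(F)(F)F)(c1ccccc1)[C@@H]1CNCCO1` differs from compound 3 in one place: (trifluoromethyl)sulfanyl in place of phenyl on an aromatic carbon.

The step of a number 21.2 percentage points lower from compound 1 to compound 3 (beyond the scatter) shows that what sits on this aromatic carbon can move the number beyond the scatter, while a number 2.6 percentage points lower from compound 2 to compound 3 (within the scatter) shows phenyl and hydrogen within the scatter of each other. For the measured compounds named here, no measured compound carries (trifluoromethyl)sulfanyl, so the direction is uncertain. Going by the values given here, the ground for expecting a rise is that the one non-ring group on this carbon is found in compound 1, which gave 24.1%. A modest rise, a number 12.1 percentage points higher from compound 3 to compound 4 (beyond the scatter), is expected. Compound 4 is estimated at 15%, range 2% to 35%.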

Compound 4, a percentage reported as inhibition, at one concentration (the size of the read-out at that concentration, not a potency): 6.2%
Compound 4: the middle estimate sits 8.8 percentage points above what was measured, within the range that was stated.
By their numbers in this assay, from the lowest: compounds 3, 2 and 4 (each within the scatter of the next); then compound 1.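

(Trifluoromethyl)sulfanyl on this aromatic carbon does not separate from phenyl (a number 3.3 percentage points higher from compound 3 to compound 4 (within the scatter)) or from hydrogen (a number 0.7 percentage points higher from compound 2 to compound 4 (within the scatter)), so having a non-ring group here is not enough to hold the number up. Bromo remains alone among the four compounds (a number 17.9 percentage points lower from compound 1 to compound 4 (beyond the scatter)), and the second non-ring group does not share its number. No measurement at hand explains this.

Going by these compounds, whether the bromo result carries over to chloro or iodo on the same aromatic carbon remains open. So does whether an amine or a carboxylic acid there would move the number at all.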